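Swapping the acid group on a cysteinyl leukotriene antagonist chain

The source may report more compounds than this note shows. Statements on the series, on what has been measured and on what is new or still open speak of the compounds shown alone.

Of the compounds shown here, two sharing one core have been measured in an in vivo functional assay on the whole organism (Rattus norvegicus) with cysteinyl leukotriene receptor (Homo sapiens) as the target; on this read-out lower numbers stand for an effect already at smaller amounts and higher numbers for an effect only at larger amounts of compound. Compound 1 `CCCc1c(COc2ccc(C(=O)CCCc3nnn[nH]3)cc2)ccc(C(C)=O)c1O` gives 7.2 mg/kg, and compound 2 `CCCc1c(COc2ccc(C(=O)CC(C)(C)CC(=O)O)cc2)ccc(C(C)=O)c1O` gives 2.9 mg/kg. On these numbers compound 2 stands lowest of the two, with the change a 2.5-fold lower number from compound 1 to compound 2 (0.39 log units; beyond the scatter). That step altered two things at once: the tetrazole ring gave way to a carboxy group, and two methyl groups appeared on the chain.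

Compound 3 `CCCc1c(COc2ccc(C(=O)CC(C)(C)Cc3nnn[nH]3)cc2)ccc(C(C)=O)c1O` has not yet been measured. It differs from compound 2 by 1H-tetrazol-5-yl in place of carboxy on a saturated chain carbon, three bonds along the chain from a carbonyl carbon, so the two methyl groups stay while the acid group is the tetrazole ring again. For the measured compounds named here, the one measured step that bears on this is the one from compound 1 to compound 2, where a move away from the tetrazole came with a modestly lower number; undoing part of that move may therefore push the number back upward, though the chain methyls remain. In this assay compound 3 is expected to show a 1.7-fold higher number from compound 2 to compound 3 (0.22 log units; within the scatter), a modest rise. The estimate for compound 3 is 4.8 mg/kg, with a likely range from 2 mg/kg to 12 mg/kg.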

Compound 3, dose for half-maximal effect: 1.3 mg/kg
The estimate for compound 3 lay 3.7-fold (0.57 log units) above the measured number; measured number below the stated range.
By their numbers in this assay, from the lowest: compound 3; then compound 2; then compound 1.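

In this assay, with the two methyl groups kept on the chain, putting 1H-tetrazol-5-yl in place of carboxy gives a 2.2-fold lower number from compound 2 to compound 3 (0.35 log units; beyond the scatter), so the lower number seen earlier on leaving the tetrazole ring did not come from the carboxy group: on this chain the tetrazole ring is the better of the two acid groups. With the tetrazole ring present at both ends of the comparison, 1-((1H-tetrazol-5-yl)methyl)-1-methylethyl in place of 2-(1H-tetrazol-5-yl)ethyl gives a 5.5-fold lower number from compound 1 to compound 3 (0.74 log units; beyond the scatter), which singles out the two chain methyl groups as the change that goes with the larger drop of the steps seen here. No measurement at hand says why either change lowers the dose needed.

Going by these compounds, how the carboxy group fares on the chain without the two methyl groups stays open, so it cannot be said whether the two changes would add up the same way with that acid. Also open, on these data alone, is whether an ethyl group in place of the methyl groups, or a longer chain leading to the tetrazole ring, would lower the number further.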